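The compounds below may be only part of what the source reports. "The series", "measured", "known", "first", "only" and "open" are said of these compounds alone.

Measured in a physicochemical assay for solubility, with a stated time of 18 h, at pH 7.4; a higher number here means a more soluble compound, a lower number a less soluble compound:
- Compound 1 `CC(C)(C)c1ccc(-c2ccc3c(NCCCNCc4ccco4)ccnc3c2)cc1`: 32000 nM
- Compound 2 `COc1ccc(F)cc1CNCCCNc1ccnc2cc(Cc3ccc(F)cc3)ccc12`: 4200 nM

Compound 2 stands lowest of these two compounds, at 4200 nM, and the gap up to compound 1 lies beyond the usual scatter. The next compound, compound 3 `COc1ccc(F)cc1CNCCCNc1ccnc2cc(-c3ccc(C(C)(C)C)cc3)ccc12`, has not yet been measured. It carries 4-(tert-butyl)phenyl in place of the 4-fluorobenzyl of compound 2 (4-(tert-butyl)phenyl in place of 4-fluorobenzyl on an aromatic carbon). The change sits on an aromatic carbon of a six-membered aromatic ring of carbon only, part of a fused or bridged system of two rings.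

Within the data shown here, no measured pair of compounds differing in one place shows what such a change does in this assay. Among the measured compounds shown here, the only guide is compound 1, which also bears 4-(tert-butyl)phenyl and gives 32000 nM, but it differs from compound 2 elsewhere too, so it offers weak support. A small rise, at about the edge of the scatter, is therefore expected. The expected change is a 1.9-fold higher number from compound 2 to compound 3 (0.28 log units; within the scatter). For compound 3 the estimated value is 8000 nM, with an expected range of 2000 nM to 30000 nM.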

Compound 3, solubility: 32000 nM
Beside the measured number, compound 3's estimate is 4.0-fold (0.60 log units) below it; the measured number lies above the stated range.
By their numbers in this assay, from the lowest: compound 2; then compounds 1 and 3 (each within the scatter of the next).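

In this assay, the step with 4-(tert-butyl)phenyl in place of 4-fluorobenzyl on an aromatic carbon is now measured directly, as a 7.6-fold higher number from compound 2 to compound 3 (0.88 log units; beyond the scatter), so this position of the shared core is shown to respond to a change of group, at least for this one pair. Among these compounds, the second new pair shows something the earlier compounds could not: 5-fluoro-2-methoxyphenyl in place of furan-2-yl on a saturated chain carbon bound to an amine nitrogen gives no change at the digits printed from compound 1 to compound 3 (within the scatter), so with 4-(tert-butyl)phenyl in place, this exchange at the other end of the molecule leaves the read-out within the scatter. Nothing measured here gives a reason for either result.

The exchange at the aromatic carbon alters the substituent on the ring and its link to the core together, so these compounds cannot separate the tert-butyl group from the loss of the benzyl carbon. As far as these compounds go, a 4-fluorophenyl or an unsubstituted phenyl at this place would help to separate them, and whether the furan-2-yl exchange stays as flat with 4-fluorobenzyl in place also remains open.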